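From 3-methylphenyl to 4-acetylphenyl in compound 3

The source may hold more compounds than are shown below. What is called first, only, known or untested is meant among the compounds shown, and "the series" means these compounds.

Among the compounds with values here, in a functional assay on A549 cells (Homo sapiens) for inhibition, read by CCK-8 assay, with a stated time of 48 h (on this read-out lower numbers stand for stronger inhibition and higher numbers for weaker inhibition), compound 1 (`COc1cc(-c2ccnc3cc(-c4ccc(F)cc4)nn23)cc(OC)c1OC`) gives 3800 nM as one of only two numbers available. Compound 2 (`COc1cc(-c2ccnc3cc(-c4cccc(C)c4)nn23)cc(OC)c1OC`) gives 5730 nM on the same read-out, which places it within the scatter of compound 1, so no order can be drawn between them.

Compound 3 (`COc1cc(-c2ccnc3cc(-c4ccc(C(C)=O)cc4)nn23)cc(OC)c1OC`) has not yet been measured. It keeps the shared core and carries 4-acetylphenyl in place of 3-methylphenyl on an aromatic carbon, and the difference from compound 2 counts as 4-acetylphenyl in place of 3-methylphenyl on an aromatic carbon in full.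

Within the data shown here, one measured step bears on this same carbon: a 1.5-fold higher number from compound 1 to compound 2 (0.18 log units; within the scatter) with 3-methylphenyl in place of 4-fluorophenyl. Among the measured compounds shown here, that step is small, but it is the only one, and no measured compound carries an acetyl group, so the data give no direction for this change. The expected step is therefore a 1.1-fold lower number from compound 2 to compound 3 (0.06 log units; within the scatter) and nothing beyond the scatter is expected in either direction. Compound 3 is estimated at 5000 nM with an expected span from 1800 nM to 14000 nM for its measurement.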

Compound 3, half-maximal inhibitory concentration: 4100 nM
Compound 3: middle estimate off by 1.2-fold (0.09 log units), on the high side; the range from low to high includes it.
By their numbers in this assay, from the lowest: compounds 1, 3 and 2 (each within the scatter of the next).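

In this assay the record now shows a 1.4-fold lower number from compound 2 to compound 3 (0.15 log units; within the scatter) and also a 1.1-fold higher number from compound 1 to compound 3 (0.03 log units; within the scatter) at this aromatic carbon, so 4-fluorophenyl, 3-methylphenyl and 4-acetylphenyl cannot be told apart on this read-out. The 4-acetylphenyl group brings a double bond outside aromatic rings and a hydrogen-bond acceptor that 3-methylphenyl lacks, yet both steps stay within the scatter, something the earlier pair, with no acetyl group, could not show. No supporting data accompany these compounds to account for this result.

On these data alone, all three compounds carry a phenyl ring at this carbon, so it remains open whether an amine, a carboxylic acid or a longer alkyl chain on that ring, or a group with no phenyl ring at all, would move the number beyond the scatter. The rest of the shared core is identical in all three compounds, so they also leave open how much a change elsewhere on it, such as replacing a methoxy group with a hydroxyl, would alter the number.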